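From Pyrimidin-2-yl to Pyrazin-2-yl: Expecting Compound 3

The source may hold more compounds than are shown below. What is called first, only, known or untested is meant among the compounds shown, and "the series" means these compounds.

Measured compounds:
compound 1 `Nc1ccccc1NC(=O)c1ccc(CSC(=S)N2CCN(Cc3ccccn3)CC2)cc1` gives 61.4%
compound 2 `Nc1ccccc1NC(=O)c1ccc(CSC(=S)N2CCN(c3ncccn3)CC2)cc1` gives 73.9%

In a functional assay on HeLa cells (Homo sapiens) for antiproliferative activity, read by CCK-8 assay, with a stated time of 72 h, tested at 8 uM (on this read-out lower numbers stand for a weaker effect and higher numbers for a stronger effect at the one concentration tested), compound 2 stands highest of the two numbers; its nearest neighbour is compound 1, and the step of a number 12.5 percentage points higher from compound 1 to compound 2 (beyond the scatter) lies beyond the scatter. Compound 3 `Nc1ccccc1NC(=O)c1ccc(CSC(=S)N2CCN(c3cnccn3)CC2)cc1` differs from compound 2 in one place: pyrazin-2-yl in place of pyrimidin-2-yl on an amine nitrogen in a ring. For the measured compounds named here, no measured step bears on this exchange of one six-membered aromatic ring with two hetero atoms for another; the only measured step, a number 12.5 percentage points higher from compound 1 to compound 2 (beyond the scatter), concerns a different replacement on the same ring nitrogen and says nothing about the pattern of the two nitrogen atoms within an aryl group that stays directly attached. The account therefore expects compound 3 to show no step beyond the scatter from compound 2 in this assay, with a number 1.9 percentage points lower from compound 2 to compound 3 (within the scatter) as the expected shift. The estimate for compound 3 is 72%, expected to fall between 58% and 84%.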

Compound 3, a percentage reported as inhibition, at one concentration (the size of the read-out at that concentration, not a potency): 76.9%
Estimate against measurement, compound 3: 4.9 percentage points below; the measured number falls inside the stated range.
By their numbers in this assay, from the lowest: compound 1; then compounds 2 and 3 (each within the scatter of the next).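

In this assay, for the compounds shown here, the exchange of pyrimidin-2-yl for pyrazin-2-yl on the amine nitrogen in a ring gives a number 3 percentage points higher from compound 2 to compound 3 (within the scatter), so this position does not separate these two arrangements of the same atoms, which the earlier compounds could not show. The second step, a number 15.5 percentage points higher from compound 1 to compound 3 (beyond the scatter), shows that the gap to (pyridin-2-yl)methyl seen with pyrimidin-2-yl is also seen with pyrazin-2-yl. Nothing available gives a reason for either step.

The compounds shown leave open whether the gap to compound 1 follows from the methylene link or from the make-up of the aromatic ring, since both differ at once. They also leave open how a directly attached pyridin-2-yl or phenyl group would compare with compound 2 and compound 3.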